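The source may hold more compounds than are shown below. What is called first, only, known or untested is meant among the compounds shown, and "the series" means these compounds.

Values so far in a functional assay on A549 cells (Homo sapiens) for antiproliferative activity, read by MTT assay, with a stated time of 48 h; on this read-out higher numbers stand for weaker inhibition and lower numbers for stronger inhibition:
Compound 1 `COc1ccc(C(=O)c2ccc(OC)c3c2C=CC(C)(C)O3)c(NC(=O)CO)c1` gives 100 nM
Compound 2 `COc1ccc(C(=O)c2ccc3c(c2)C=CC(C)(C)O3)c(NC(=O)CO)c1` gives 90 nM
Compound 3 `COc1ccc(C(=O)c2ccc(OC)c3c2C=CC(C)(C)O3)c(NC(=O)CN)c1` gives 420 nM

Compound 3, at 420 nM here, has the highest number of the three, so it is the weakest inhibitor among them, and both gaps lie beyond the usual scatter. Compound 4 `CCNCC(=O)Nc1cc(OC)ccc1C(=O)c1ccc(OC)c2c1C=CC(C)(C)O2` has not been measured yet. It departs from compound 3 in one place (ethyl in place of hydrogen on an amine nitrogen), with ethyl in place of hydrogen on an amine nitrogen.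

Among the measured compounds shown here, only one measured step touches this part of the molecule. The change a 4.2-fold higher number from compound 1 to compound 3 (0.62 log units; beyond the scatter) came with amino in place of hydroxy on a saturated chain carbon, and it was modest. For the measured compounds named here, no measured compound carries any group on that amine nitrogen, so this step is only a loose guide. Going by it, a small rise in the number is expected in this assay rather than a large one, and the rise may stay within the scatter. The estimated move is a 1.2-fold higher number from compound 3 to compound 4 (0.08 log units; within the scatter) in size. For compound 4 the expected value is 500 nM with an estimated range from 180 nM to 1500 nM across repeated measurements.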

Compound 4, half-maximal inhibitory concentration: 2310 nM
The estimate for compound 4 lay 4.6-fold (0.66 log units) below the measured number; the measured number lies above the stated range.
By their numbers in this assay, from the lowest: compounds 2 and 1 (each within the scatter of the next); then compound 3; then compound 4.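

In this assay, the amine nitrogen of this side chain does not tolerate every replacement of its hydrogen: ethyl there brings a 5.5-fold higher number from compound 3 to compound 4 (0.74 log units; beyond the scatter), a step beyond the scatter. The two changes on this chain push the number the same way, and ethylamino in place of hydroxy amounts to a 23-fold higher number from compound 1 to compound 4 (1.36 log units; beyond the scatter), so the ethyl adds to the loss already seen with the simple amino group. No measurement at hand explains this loss of inhibition.

As far as these compounds go, it remains open whether the rise follows the size of the group on that nitrogen, which methyl, propyl or a ring amine such as morpholine could test. From the compounds shown here alone, it is also open whether amino and ethylamino act the same way on the core of compound 2.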